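A Single Fluoro Change on Compound 2

The source may hold more compounds than are shown below. What is called first, only, known or untested is meant among the compounds shown, and "the series" means these compounds.

Compound 1 (`CC(Oc1ccc(Cl)cc1Cl)C(=O)Nc1ccc(F)cc1`) has no number ("not determined" (no result reported))
Compound 2 (`CC(Oc1ccc(Cl)cc1Cl)C(=O)NCc1ccccc1`) has a measured value (95000 nM)

For the measured compounds named here, in an ADME assay on CHO cells (Cricetulus griseus) for cytotoxicity, read by LDH release (on this read-out higher numbers stand for weaker inhibition and lower numbers for stronger inhibition), compound 2 (95000 nM) holds the only number, so no ranking exists. Compound 3 (`CC(Oc1ccc(Cl)cc1Cl)C(=O)NCc1cccc(F)c1`) differs from compound 2 by one change (fluoro in place of hydrogen on an aromatic carbon), fluoro in place of hydrogen on an aromatic carbon, turning phenyl into 3-fluorophenyl. Going by the values given here, no measured pair shows what such a change does in this assay. Nothing beyond the usual scatter is expected, and the estimated step (a 1.2-fold lower number from compound 2 to compound 3 (0.07 log units; within the scatter)) leans only slightly toward stronger inhibition. Compound 3 is expected at about (80000 nM), with an estimated range from (40000 nM) to (150000 nM).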

Compound 3, half-maximal inhibitory concentration: 27000 nM
Beside the measured number, compound 3's estimate is 3.0-fold (0.47 log units) above it, and the stated range ends above it.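

In this assay, fluoro in place of hydrogen on an aromatic carbon, turning phenyl into 3-fluorophenyl, gives a 3.5-fold lower number from compound 2 to compound 3 (0.55 log units; beyond the scatter) and so shows that this position responds to this change, toward stronger inhibition. For the compounds shown here, this is the only measured pair here, and it gives the change its first measured size in this assay. Nothing available explains the step. On these data alone, whether a chlorine or a methoxy group at this position would move the number the same way remains open, as does the effect of fluoro elsewhere on the ring.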